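Swapping a Side Chain on a Bcl-2 Binder

This account rests on a few compounds, and the source may have more. Where it says the series, first, only, none or still open, it means among the compounds named here.

Three compounds have been measured in an assay on isolated protein for displacement of a labelled ligand from Apoptosis regulator Bcl-2 (Homo sapiens), with a stated time of 15 min; a lower number here means a stronger inhibitor, a higher number a weaker inhibitor:
compound 1 `CC1(C)CCC(CN2CCN(c3ccc(C(=O)NS(=O)(=O)c4ccc(NCC5CCOCC5)c([N+](=O)[O-])c4)c(Oc4cnc5[nH]ccc5c4)c3)CC2)=C(c2ccc(Cl)cc2C(F)(F)F)C1`, 0.86 nM
compound 2 `CC1(C)CCC(CN2CCN(c3ccc(C(=O)NS(=O)(=O)c4ccc(NCC5CCOCC5)c([N+](=O)[O-])c4)c(Oc4cnc5[nH]ccc5c4)c3)CC2)=C(c2ccccc2C(F)(F)F)C1`, 1.7 nM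
compound 3 `CC1(C)CCC(CN2CCN(c3ccc(C(=O)NS(=O)(=O)c4ccc(NCC5CCOC5)c([N+](=O)[O-])c4)c(Oc4cnc5[nH]ccc5c4)c3)CC2)=C(c2ccc(C(F)(F)F)cc2)C1`, 4.7 nM

Compound 3 gives the highest of the three numbers in this assay, beyond the scatter from both compound 2 and compound 1. Going by the values given here, the only single-point step among them, a 2.0-fold higher number from compound 1 to compound 2 (0.30 log units; within the scatter), concerns a different part of the molecule. Compound 4 `CN1CCC(COc2ccc(S(=O)(=O)NC(=O)c3ccc(N4CCN(CC5=C(c6ccc(C(F)(F)F)cc6)CC(C)(C)CC5)CC4)cc3Oc3cnc4[nH]ccc4c3)cc2[N+](=O)[O-])C1` differs from compound 3 by (1-methylpyrrolidin-3-yl)methoxy in place of ((oxolan-3-yl)methyl)amino on an aromatic carbon. Among the compounds with values here, no measured step bears on this position, so nothing in the data points to a change in either direction beyond the scatter. The estimate for compound 4 is therefore close to compound 3: a 1.1-fold higher number from compound 3 to compound 4 (0.03 log units; within the scatter), giving an expected value of 5 nM with a range of 1.5 nM to 16 nM.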

Compound 4, half-maximal inhibitory concentration: 0.75 nM
Compound 4: middle estimate off by 6.7-fold (0.82 log units), on the high side; measured number below the stated range.
By their numbers in this assay, from the lowest: compounds 4, 1 and 2 (each within the scatter of the next, the first and the last beyond it); then compound 3.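

In this assay, the side chain on the aromatic carbon ortho to a nitro group proves able to move the number: (1-methylpyrrolidin-3-yl)methoxy in place of ((oxolan-3-yl)methyl)amino gives a 6.3-fold lower number from compound 3 to compound 4 (0.80 log units; beyond the scatter), beyond the scatter. The change removes the hydrogen-bond donor of the leaving group, and the number does not rise. No available evidence accounts for this step.

The compounds shown do not separate the swap of the linking amine for an ether oxygen from the swap of the ring. A (1-methylpyrrolidin-3-yl)methylamino chain at this position would divide the two.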